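Swapping the para substituent on the aryl ketone of compound 3

A few compounds are considered here, and "the series" means these few. Any claim that something is new, unique, unknown or untested is made for them only; others in the source may bear on it.

Compound 1 `O=C(/C=C/c1ccc2c(c1)B(O)OC2)c1cccnc1`: 34400 nM
Compound 2 `O=C(/C=C/c1ccc2c(c1)B(O)OC2)c1ccc(I)cc1`: > 100000 nM, a limit of the assay
Compound 3 `CSc1ccc(C(=O)/C=C/c2ccc3c(c2)B(O)OC3)cc1`: 7400 nM

In a toxicity assay on MCF-10A cells (Homo sapiens) for cytotoxicity, read by MTT assay, with a stated time of 48 h (on this read-out higher numbers stand for weaker inhibition and lower numbers for stronger inhibition), compound 3 gives the lowest number of the two measured values, with compound 1 giving 34400 nM. Compound 4 `O=C(/C=C/c1ccc2c(c1)B(O)OC2)c1ccc(O)cc1` differs from compound 3 by hydroxy in place of methylsulfanyl on an aromatic carbon. For the measured compounds named here, the one measured step at this position, an at least 13-fold lower number from compound 2 to compound 3 (1.13 log units; beyond the scatter), shows that a change here can move the number a great deal, though the earlier step of an at least 2.9-fold higher number from compound 1 to compound 2 (0.46 log units; beyond the scatter) concerned a different part of the molecule and does not reach the limit of > 100000 nM in this assay, at which 1 of the 3 values shown sits, in the same way. Going by the values given here, no measured step involves a hydroxy group, so the direction for compound 4 is uncertain; a modest rise in the number is estimated, a 2.7-fold higher number from compound 3 to compound 4 (0.43 log units; beyond the scatter), giving compound 4 an expected value of 20000 nM with a range from 5000 nM to 100000 nM.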

Compound 4, half-maximal inhibitory concentration: 24800 nM
Compound 4: the middle estimate sits 1.2-fold (0.09 log units) below what was measured; the range from low to high includes it.
By their numbers in this assay, from the lowest: compound 3; then compounds 4 and 1 (each within the scatter of the next). At a limit, above all of these: compound 2.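

In this assay, hydroxy in place of methylsulfanyl gives a 3.4-fold higher number from compound 3 to compound 4 (0.53 log units; beyond the scatter), while hydroxy in place of iodo gives an at least 4.0-fold lower number from compound 2 to compound 4 (0.60 log units; beyond the scatter), so this position now has a step between two exact values as well as one against iodo. The value of compound 2 is a limit, so the second step is only a bound: the limit of > 100000 nM in this assay, at which 1 of the 4 values shown sits. Changing the whole aryl group, 4-hydroxyphenyl in place of pyridin-3-yl gives a 1.4-fold lower number from compound 1 to compound 4 (0.14 log units; within the scatter), which separates neither compound from the other. The compounds shown leave open how an amine, a carboxylic acid or a longer sulfur-linked chain would read at this position.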